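Extending the vinyl group on the amide of compound 2

This account rests on a few compounds, and the source may have more. Where it says the series, first, only, none or still open, it means among the compounds named here.

Compound 1 (`C=CC(=O)Nc1cccc(Oc2nc(Nc3cccc(OC)c3)nc3ccsc23)c1`) and compound 2 (`C=CC(=O)Nc1cccc(Oc2nc(Nc3cccc(C#N)c3)nc3ccsc23)c1`) share one core and differ only at one aromatic carbon. In a functional assay on MCF7 cells (Homo sapiens) for inhibition, read by MTT assay, with a stated time of 72 h (on this read-out lower numbers stand for stronger inhibition and higher numbers for weaker inhibition), compound 1 gives 19000 nM. In this assay compound 2 gives 19000 nM. The step of no change at the digits printed from compound 1 to compound 2 (within the scatter) shows that swapping those two groups made no difference that the scatter could not explain, so compound 2 stands level with compound 1.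

Compound 3 (`CC(C)/C=C/C(=O)Nc1cccc(Oc2nc(Nc3cccc(C#N)c3)nc3ccsc23)c1`) keeps everything in compound 2 except the group on the amide carbonyl: 3-methylbut-1-en-1-yl in place of vinyl on a carbonyl carbon. Within the data shown here, this change sits at the amide end of the molecule, far from the aromatic carbon where compound 1 and compound 2 differ, so the one measured step gives no direct guide to it; the only evidence is that the shared core held a weak value through the step already seen.

Without a comparable measured step, the expectation for compound 3 is a value close to that of compound 2, with the step of a 1.3-fold higher number from compound 2 to compound 3 (0.12 log units; within the scatter) likely staying within the scatter. Compound 3 is therefore estimated at 25000 nM, with a range from 8000 nM to 80000 nM.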

Compound 3, half-maximal inhibitory concentration: > 50000 nM
Compound 3 gave a limit, no number; the forecaster's own chance of this, stated with the estimate: 10%; middle value at least 2.0-fold (0.30 log units) away from the limit.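

In this assay, 3-methylbut-1-en-1-yl in place of vinyl on a carbonyl carbon gives an at least 2.6-fold higher number from compound 2 to compound 3 (0.42 log units; beyond the scatter), a shift towards weaker inhibition that lies beyond the usual scatter. The earlier pair showed only that the read-out did not respond to a swap at one aromatic carbon, whereas this step shows that it does respond to a change in the group on the amide carbonyl, and that this larger carbon group goes with the weaker side of the scale. The reading for compound 3 is a limit of the assay and not a number, so this step gives only a lower bound on the size of the change: the limit of > 50000 nM in this assay, at which 1 of the 3 values shown sits.

Going by these compounds, with just vinyl and 3-methylbut-1-en-1-yl to compare at this position, it remains open whether the loss follows the number of added carbons, the branching at the end of the chain, or the substitution on the double bond itself. On these data alone, it is also open how a chain ending in an amine, such as a dimethylamino group, would read here, and whether the same swap would have a similar effect with methoxy in place of the nitrile.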